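The source may report more compounds than this note shows. Statements on the series, on what has been measured and on what is new or still open speak of the compounds shown alone.

Measured so far:
compound 1 `C[Se]/C(=N\C(=O)c1cccs1)NC(=O)c1cccs1` — 630 nM
compound 2 `CS/C(=N\C(=O)c1csc([N+](=O)[O-])c1)NC(=O)c1csc([N+](=O)[O-])c1` — 63400 nM

In a functional assay on HepG2 cells (Homo sapiens) for cytotoxicity, read by MTT assay, with a stated time of 72 h (on this read-out higher numbers stand for weaker inhibition of growth and lower numbers for stronger inhibition of growth), compound 1 gives 630 nM. Compound 2, with 63400 nM, holds the highest of the two numbers; its nearest neighbour is compound 1, far below it and beyond the scatter. Among the compounds with values here, the two compounds differ in more than one place, so no single step between them is drawn.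

Compound 3 `C[Se]/C(=N\C(=O)c1csc([N+](=O)[O-])c1)NC(=O)c1csc([N+](=O)[O-])c1` has not yet been measured. It differs from compound 2 in one place: a group of 2 heavy atoms (1 carbon, 1 selenium; no ring) in place of a group of 2 heavy atoms (1 carbon, 1 sulfur; no ring), on a carbon with a double bond to nitrogen. Within the data shown here, the only other compound carrying selenium, compound 1, gives 630 nM, but it also differs elsewhere, so the share of this change alone is unknown. A moderate fall in number, beyond the scatter, is expected for compound 3. Its step is expected to be a 4.2-fold lower number from compound 2 to compound 3 (0.63 log units; beyond the scatter). The estimate for compound 3 is 15000 nM, within a range from 3000 nM to 60000 nM.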

Compound 3, concentration for 50% growth inhibition: 620 nM
Beside the measured number, compound 3's estimate is 24-fold (1.38 log units) above it, outside the stated range (below it).
By their numbers in this assay, from the lowest: compounds 3 and 1 (each within the scatter of the next); then compound 2.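

In this assay, the only difference between the two compounds of this pair is methylsulfanyl giving way to its selenium counterpart, on a carbon with a double bond to nitrogen whose other neighbours are two amide-type nitrogens, and this gives a 100-fold lower number from compound 2 to compound 3 (2.01 log units; beyond the scatter). The earlier compounds shown here differed in more than one place and could not isolate this exchange, whereas this pair assigns the whole step to it. Within this pair, the read-out at this position is therefore highly sensitive to exchanging sulfur for selenium, with the rest of the structure unchanged. Nothing available gives a reason for the size of this step. Still open, going by these compounds, is how an amine or a longer chain at the same carbon would read out, and whether the exchange has a similar effect on the core of compound 1.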